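The compounds below may be only part of what the source reports. "The series", "measured", "known", "first", "only" and "open" are said of these compounds alone.

Measured compounds in an ADME assay on BJ cells (Homo sapiens) for cytotoxicity, with a stated time of 72 h; a higher number here means that more compound is needed for the effect, a lower number that less compound is needed:
Compound 1, `Cc1cc(NC(=O)Nc2cc(F)ccc2F)c2ccccc2n1`, gives 7000 nM.
Compound 2, `Cc1cc(NC(=O)Nc2ccccc2C(F)(F)F)c2ccccc2n1`, reaches only the limit of this assay, > 25000 nM.
Compound 3, `Cc1cc(NC(=O)Nc2ccccc2F)c2ccccc2n1`, likewise reaches only the limit of this assay, > 25000 nM.

Compound 3 thus stands at the limit, the point described by the limit of > 25000 nM in this assay, at which 2 of the 3 values shown sit, and no exact number is known for it. Compound 4, `Cc1cc(NC(=O)Nc2ccccc2OC(F)(F)F)c2ccccc2n1`, differs from compound 3 in one place: trifluoromethoxy in place of fluoro on an aromatic carbon. Two measured steps lead into compound 3. The step of an at least 3.5-fold higher number from compound 1 to compound 3 (0.55 log units; beyond the scatter) shows the number rising at least modestly. The step that the two limits leave unreadable from compound 2 to compound 3 gives no readable size. For the measured compounds named here, no measured step puts a trifluoromethoxy on this ring, so no direction can be read from them. Compound 4 is expected to remain near the limit, with a number no higher from compound 3 to compound 4 (the limit leaves the size open). The estimate for compound 4 is 25000 nM, between 8000 nM and 60000 nM.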

Compound 4, half-maximal effective concentration: > 25000 nM
Compound 4: only a limit was reported (the forecaster's own chance of this, stated with the estimate: 60%); the middle value lies on the limit itself.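

Compound 4, like compound 2 and compound 3, gives only a limit in this assay, and no step among these three compounds can be read. The compounds shown leave open whether these three truly differ.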